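From pyridin-3-yl to pyridin-2-yl on the shared core

The source may report more compounds than this note shows. Statements on the series, on what has been measured and on what is new or still open speak of the compounds shown alone.

In an ADME assay on S9 fraction from liver (Rattus norvegicus) for metabolic stability, read by LC-MS, using NADPH, with a stated time of 30 min (a lower number here means that less of the compound is left, a higher number that more of the compound is left), compound 1 `CCCCCCCCc1ccc(OCC(=O)Cn2nnnc2C)cc1` gives 32%, compound 2 `CCCCCCCCc1ccc(OCC(=O)Cn2nnnc2SC)cc1` gives 21% and compound 3 `CCCCCCCCc1ccc(OCC(=O)Cn2nnnc2-c2cccnc2)cc1` gives 20%. Compound 3 has the lowest number of the three, but only the gap to compound 1 counts: the data show a number 12 percentage points lower from compound 1 to compound 3 (beyond the scatter), whereas a number 1 percentage points lower from compound 2 to compound 3 (within the scatter) leaves compound 3 and compound 2 indistinguishable. The remaining measured step is a number 11 percentage points lower from compound 1 to compound 2 (beyond the scatter).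

Compound 4 `CCCCCCCCc1ccc(OCC(=O)Cn2nnnc2-c2ccccn2)cc1` is related to compound 3 by pyridin-2-yl in place of pyridin-3-yl on an aromatic carbon. Among the compounds with values here, no measured pair tests this kind of exchange directly. The two modest steps both start from the methyl of compound 1, so they say little about swapping one pyridinyl group for another. The closest guide is the exchange at the same place between compound 2 and compound 3, which gave a number 1 percentage points lower from compound 2 to compound 3 (within the scatter). No step beyond the scatter is therefore expected in this assay, and the expected outcome is no change at the digits printed from compound 3 to compound 4 (within the scatter). For compound 4 the estimated value is 20%, with an expected range from 10% to 31%.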

Compound 4, percent of the compound remaining: < 5%
Compound 4 ended at the assay's limit; the forecaster's own chance of this, stated with the estimate: 3%; middle value at least 15 percentage points away from the limit.
By their numbers in this assay, from the lowest: compounds 3 and 2 (each within the scatter of the next); then compound 1. At a limit, below all of these: compound 4.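

In this assay, within the data shown here, the exchange of pyridin-3-yl for pyridin-2-yl, which keeps the same atoms joined differently, gives a number at least 15 percentage points lower from compound 3 to compound 4 (beyond the scatter), so at this place on the shared core the way the pyridinyl group is attached matters, something the earlier compounds could not show. The other new steps are a number at least 16 percentage points lower from compound 2 to compound 4 (beyond the scatter) and a number at least 27 percentage points lower from compound 1 to compound 4 (beyond the scatter), which set the pyridin-2-yl group apart from the methylsulfanyl and pyridin-3-yl groups, themselves within the scatter of each other. Compound 4 gives < 5%, which is a limit of the assay and not a number, so the full size of these steps remains unknown: the limit of < 5% in this assay, at which 1 of the 4 values shown sits.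

What separates the two pyridinyl groups is not settled by these compounds. They also leave open how a phenyl group, an amine or a carboxylic acid at this place would read in this assay.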